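Adding a Methoxy Group to Compound 2

The compounds below may be only part of what the source reports. "The series", "measured", "known", "first", "only" and "open" are said of these compounds alone.

Before a new compound is tested, the values already in hand offer a starting point, and here there are only two, both from an ADME assay on MDBK cells (Bos taurus) for cytotoxicity, read by MTT assay, with a stated time of 96 h; on this read-out higher numbers stand for lower toxicity in this test and lower numbers for higher toxicity in this test. Compound 1 `COc1ccc(-c2nc3cc(C(C)O)ccc3[nH]2)cc1` gives > 100000 nM, which is a limit and not a measured number. Among the measured compounds shown here, compound 2 `C/C(=N\NC(N)=S)c1ccc2[nH]c(-c3ccccc3)nc2c1` gives 32000 nM, the only actual number so far, so there is no series of numbers in which to rank it.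

Compound 3 `COc1ccc(-c2nc3cc(/C(C)=N/NC(N)=S)ccc3[nH]2)cc1` differs from compound 2 in one place: methoxy in place of hydrogen on an aromatic carbon. This is methoxy in place of hydrogen on an aromatic carbon, para to a large group, turning phenyl into 4-methoxyphenyl.

For the measured compounds named here, no measured pair of compounds shows what this change does in this assay, so compound 2 at 32000 nM remains the natural anchor for a prediction. The step of no change at the digits printed from compound 2 to compound 3 (within the scatter) is expected to stay within the usual scatter of repeated measurements, with no direction favoured. For compound 3 the estimated value is 32000 nM, with an expected range from 12000 nM to 85000 nM.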

Compound 3, half-maximal cytotoxic concentration: 13000 nM
Compound 3: middle estimate off by 2.5-fold (0.39 log units), on the high side; the measured number falls inside the stated range.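

With methoxy in place of hydrogen on an aromatic carbon, para to a large group, this assay now has its first measured change at this position: a 2.5-fold lower number from compound 2 to compound 3 (0.39 log units; beyond the scatter). Turning phenyl into 4-methoxyphenyl therefore moves the number beyond the scatter, towards higher toxicity in this test. With 4-methoxyphenyl held fixed, putting a group of 7 heavy atoms in place of a group of 3 heavy atoms on an aromatic carbon gives an at least 7.6-fold lower number from compound 1 to compound 3 (0.88 log units; beyond the scatter), a size that is only a minimum, as compound 1 stands at a limit and not at a number: the limit of > 100000 nM in this assay, at which 1 of the 3 values shown sits.

Nothing shown gives a reason for the methoxy step, and a single pair cannot tell whether it is specific to methoxy or whether a hydroxyl, a chlorine, an amine or a longer chain such as ethoxy in the same place would move the number as far or in the same direction. Among the compounds shown here, also open is whether methoxy would have a similar effect elsewhere on that ring, or on a compound with a different group in place of the one shared by compound 2 and compound 3.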